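The source may report more compounds than this note shows. Statements on the series, on what has been measured and on what is new or still open speak of the compounds shown alone.

In an ADME assay on HepG2 cells (Homo sapiens) for cytotoxicity, read by MTT assay, with a stated time of 24 h (on this read-out lower numbers stand for higher toxicity in this test and higher numbers for lower toxicity in this test), compound 1 `Cc1ccc(-c2cn(-c3ccnc4cc(Cl)ccc34)nn2)cc1` gives 352000 nM. Compound 2 `Clc1ccc2c(-n3cc(C4CCCCC4)nn3)ccnc2c1` carries a cyclohexyl in place of the 4-methylphenyl of compound 1 on an aromatic carbon. For compound 2 this assay reports only a limit, > 3200 nM. Because of the limit of > 3200 nM in this assay, at which 1 of the 2 values shown sits, the step that the limit leaves unreadable from compound 1 to compound 2 cannot be read, so compound 2 has no fixed point on the scale, only a limit. Compound 3 `CN(C)Cc1cn(-c2ccnc3cc(Cl)ccc23)nn1` differs from compound 2 by (dimethylamino)methyl in place of cyclohexyl on an aromatic carbon. No measured step bears on this exchange: the single step shown, from compound 1 to compound 2, is unreadable and concerns a different pair of groups. The expectation for compound 3 therefore rests on the two values alone, one a number and one a limit, and gives no reason to expect a step in either direction beyond the scatter. The estimate for compound 3 in this assay is 100000 nM, with a range from 10000 nM to 400000 nM. This estimate means an expected step that the limit leaves unreadable from compound 2 to compound 3, with a real chance that compound 3, like compound 2, returns only a limit.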

Compound 3, half-maximal cytotoxic concentration: 1850000 nM
Estimate against measurement, compound 3: 19-fold (1.27 log units) below; measured number above the stated range.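

Within the data shown here, the one readable new step concerns the exchange of 4-methylphenyl for (dimethylamino)methyl on an aromatic carbon of the five-membered aromatic ring: in this assay it gives a 5.3-fold higher number from compound 1 to compound 3 (0.72 log units; beyond the scatter). A higher number here stands for lower toxicity in this test, so this position is not indifferent to the group it carries, and a group with no ring can give a higher number than the 4-methylphenyl of compound 1. Compound 2 cannot join this comparison, and the steps that involve it cannot be read, because its value is only a limit: the limit of > 3200 nM in this assay, at which 1 of the 3 values shown sits.

The exchange from compound 1 to compound 3 removes a ring and brings in a nitrogen together, and the compounds shown do not separate these two changes. Going by these compounds, it also remains open how this test would read with a longer chain ending in the same dimethylamino group, or with a carboxylic acid, on this aromatic carbon.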